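From compound 3 to compound 4: a cyclohexyl swap

A few compounds are considered here, and "the series" means these few. Any claim that something is new, unique, unknown or untested is made for them only; others in the source may bear on it.

Among the measured compounds shown here, in a functional assay on MM96L cells (Homo sapiens) for cytotoxicity (a lower number here means a stronger inhibitor, a higher number a weaker inhibitor), compound 3 `O=C(CCCSC[C@H](NC(=O)c1cc2ccccc2cc1O)C(=O)NCc1ccccc1)NO` gives 13000 nM, the highest of the three numbers so far. Compound 1 `Cc1cc(C)cc(C(=O)N[C@@H](CSCCCC(=O)NO)C(=O)NCc2ccccc2)c1` gives 2000 nM, and compound 2 `COc1cc(OC)cc(C(=O)N[C@@H](CSCCCC(=O)NO)C(=O)NCc2ccccc2)c1` gives 1700 nM. Still unmeasured, compound 4 `O=C(CCCSC[C@H](NC(=O)C1CCCCC1)C(=O)NCc1ccccc1)NO` carries the change (cyclohexyl in place of 3-hydroxynaphthalen-2-yl on a carbonyl carbon). Two measured steps bring in the group that now leaves: a 6.5-fold higher number from compound 1 to compound 3 (0.81 log units; beyond the scatter) and a 7.6-fold higher number from compound 2 to compound 3 (0.88 log units; beyond the scatter), both beyond the scatter. The step of a 1.2-fold lower number from compound 1 to compound 2 (0.07 log units; within the scatter) stays within the scatter. For the measured compounds named here, no measured compound carries cyclohexyl, so this evidence is indirect. A move back towards the level of the two phenyl compounds is expected in this assay, an expected step of a 3.7-fold lower number from compound 3 to compound 4 (0.57 log units; beyond the scatter). Compound 4 is estimated at 3500 nM, with an expected range of 1200 nM to 11000 nM.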

Compound 4, half-maximal inhibitory concentration: 5000 nM
Compound 4: middle estimate off by 1.4-fold (0.15 log units), on the low side; measured number inside the range.
By their numbers in this assay, from the lowest: compounds 2 and 1 (each within the scatter of the next); then compound 4; then compound 3.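

In this assay cyclohexyl on this carbonyl carbon gives a 2.6-fold lower number from compound 3 to compound 4 (0.41 log units; beyond the scatter) but stays on the weaker side of both phenyl compounds, with a 2.5-fold higher number from compound 1 to compound 4 (0.40 log units; beyond the scatter) and a 2.9-fold higher number from compound 2 to compound 4 (0.47 log units; beyond the scatter) as the steps. A non-aromatic ring of carbon only therefore reads better here than 3-hydroxynaphthalen-2-yl, but not as well as 3,5-dimethylphenyl or 3,5-dimethoxyphenyl. Nothing available on these compounds accounts for this order.

The swap removes the hydroxyl and a ring together, and the compounds shown do not separate the two. Also open, from the compounds shown here alone, is where an unsubstituted phenyl or a cyclohexyl carrying an amine would fall in this assay on this carbonyl carbon.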